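This account rests on a few compounds, and the source may have more. Where it says the series, first, only, none or still open, it means among the compounds named here.

Compound 3 `CCn1cc(C(=O)O)c(=O)c2cc(F)c(N3CCN(C(=N)NS(=O)(=O)c4ccc(C(F)(F)F)cc4)CC3)cc21` stands level with compound 1 `N=C(NS(=O)(=O)c1ccc(Cl)cc1)N1CCN(c2cc3c(cc2F)c(=O)c(C(=O)O)cn3C2CC2)CC1` and compound 2 `N=C(NS(=O)(=O)c1ccc(C(F)(F)F)cc1)N1CCN(c2cc3c(cc2F)c(=O)c(C(=O)O)cn3C2CC2)CC1` in a functional assay on A549 cells (Homo sapiens) for antiproliferative activity, read by MTT assay, with a stated time of 72 h; on this read-out lower numbers stand for stronger inhibition and higher numbers for weaker inhibition: compound 1 gives 71 nM, compound 2 gives 71 nM and compound 3 gives 71 nM. Compound 4 `CCn1cc(C(=O)O)c(=O)c2cc(F)c(N3CCN(C(=N)NS(=O)(=O)c4ccccc4)CC3)cc21` differs from compound 3 by hydrogen in place of trifluoromethyl on an aromatic carbon. The step of no change at the digits printed from compound 1 to compound 2 (within the scatter) bears on this most directly, as it also exchanged the group on that aromatic carbon, trifluoromethyl in place of chloro, and stayed within the scatter; the step of no change at the digits printed from compound 2 to compound 3 (within the scatter) sits elsewhere and likewise stayed within the scatter. One exchange at this carbon has left the read-out unmoved, so for compound 4 no step beyond the scatter is expected, no change at the digits printed from compound 3 to compound 4 (within the scatter). Compound 4 is estimated at 71 nM, with a range of 35 nM to 145 nM.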

Compound 4, half-maximal inhibitory concentration: 71 nM
Compound 4: middle estimate and measured number agree at the digits printed; measured number inside the range.
By their numbers in this assay, from the lowest: compounds 1, 2, 3 and 4 (each within the scatter of the next).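

Going from 4-(trifluoromethyl)phenyl to phenyl gives no change at the digits printed from compound 3 to compound 4 (within the scatter) in this assay, which extends the earlier picture. The earlier exchange only set one group against another, whereas here the aromatic carbon para to a large group carries hydrogen alone, so with ethyl on the aromatic nitrogen the read-out does not depend on a group at this carbon. Still open, on these data alone, is whether an amine, a carboxylic acid or a longer chain at this carbon would leave the read-out level, and whether hydrogen behaves alike with cyclopropyl on the aromatic nitrogen. No measurement at hand accounts for this flat read-out.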